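Acyl variation on the aminopyrrole nitrogen: compound 4

The compounds below may be only part of what the source reports. "The series", "measured", "known", "first", "only" and "open" are said of these compounds alone.

Compound 1 `N#Cc1c(-c2ccccc2)cn(-c2ccc(S(=O)(=O)Nc3nccs3)cc2)c1N` in a functional assay on HepG2 cells (Homo sapiens) for inhibition, read by sulforhodamine B assay, with a stated time of 24 h (on this read-out higher numbers stand for weaker inhibition and lower numbers for stronger inhibition), gives 5360 nM. Compound 2 `N#Cc1c(-c2ccccc2)cn(-c2ccc(S(=O)(=O)Nc3nccs3)cc2)c1NC(N)=O`, which carries a carbamoyl on that ring nitrogen, gives 4020 nM in this assay; the step is a 1.3-fold lower number from compound 1 to compound 2 (0.12 log units; within the scatter). Compound 3 `N#Cc1c(-c2ccccc2)cn(-c2ccc(S(=O)(=O)Nc3ccccn3)cc2)c1NC(N)=O` gives 4120 nM in this assay, and the step is a 1.0-fold higher number from compound 2 to compound 3 (0.01 log units; within the scatter). Compound 2 holds the lowest number of the three, but both other compounds sit within the scatter of it, so no order among compounds 1, 2 and 3 can be read from these values.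

Compound 4 `N#Cc1c(-c2ccccc2)cn(-c2ccc(S(=O)(=O)Nc3nccs3)cc2)c1NC(=O)CCC(=O)O` is not yet measured. Against compound 2 the change is 2-carboxyethyl in place of amino on a carbonyl carbon. Within the data shown here, the only measured step touching the substituent on that nitrogen is a 1.3-fold lower number from compound 1 to compound 2 (0.12 log units; within the scatter), which stayed within the scatter; the exchange of the heteroaryl on the sulfonamide nitrogen, a 1.0-fold higher number from compound 2 to compound 3 (0.01 log units; within the scatter), likewise stayed within it. Nothing measured here separates a longer acyl chain bearing a carboxylic acid from the carbamoyl. Compound 4 is therefore expected to sit close to compound 2, with no step beyond the scatter. The expected step is a 1.1-fold higher number from compound 2 to compound 4 (0.05 log units; within the scatter). For compound 4 the estimate in this assay is 4500 nM, with an expected range from 2000 nM to 10000 nM.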

Compound 4, half-maximal inhibitory concentration: 3750 nM
The estimate for compound 4 lay 1.2-fold (0.08 log units) above the measured number, within the range that was stated.
By their numbers in this assay, from the lowest: compounds 4, 2, 3 and 1 (each within the scatter of the next).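

On the nitrogen on an aromatic ring, the series now spans hydrogen, carbamoyl and (2-carboxyethyl)carbonyl, and in this assay all three remain within the scatter of one another. The exchange on the carbonyl carbon gives a 1.1-fold lower number from compound 2 to compound 4 (0.03 log units; within the scatter), and the full replacement of hydrogen on the nitrogen gives a 1.4-fold lower number from compound 1 to compound 4 (0.16 log units; within the scatter), so neither the step from amino to 2-carboxyethyl nor the larger change from the free amino compound separates the values. No supporting measurement bears on why the read-out stays flat across these substituents.

Open, going by these compounds, is whether any group at this position moves the number beyond the scatter, for example a longer chain ending in a carboxylic acid, a chain ending in an amine, or a methyl ester in place of the free acid. Also open, on these data alone, is whether the (2-carboxyethyl)carbonyl group behaves the same way with pyridin-2-yl on the sulfonamide nitrogen, and whether a substituent elsewhere on the shared core, such as on its phenyl group, has a larger effect on the number than the changes at this nitrogen.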